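The source may report more compounds than this note shows. Statements on the series, on what has been measured and on what is new or still open speak of the compounds shown alone.

Three imines sharing one core have been measured in an assay on isolated protein for inhibition of Amine oxidase [flavin-containing] B (Homo sapiens), read by fluorescence and Amplex Red, with stated times of 15 min and 20 min; on this read-out higher numbers stand for weaker inhibition and lower numbers for stronger inhibition. Compound 1 `Oc1cccc(/C=N/c2ccc(OCc3ccccc3)cc2)c1O` gives 6870 nM in this assay. Compound 2 `Cc1ccc(/C=N/c2ccc(OCc3ccccc3)cc2)c(O)c1` gives 24400 nM, and the single-place change from compound 1 to compound 2, 2-hydroxy-4-methylphenyl in place of 2,3-dihydroxyphenyl on a carbon with a double bond to nitrogen, gives a 3.6-fold higher number from compound 1 to compound 2 (0.55 log units; beyond the scatter). Compound 3 `O=[N+]([O-])c1ccc(O)c(/C=N/c2ccc(OCc3ccccc3)cc2)c1` gives 60900 nM, the highest of the three numbers, beyond the scatter from compound 2 and further still from compound 1.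

Compound 4 `Oc1ccccc1/C=N/c1ccc(OCc2ccccc2)cc1` differs from compound 3 by hydrogen in place of nitro on an aromatic carbon, meta to a large group and para to a hydroxy group. No measured step removes a nitro group; the only single-place step shown, from compound 1 to compound 2 with a 3.6-fold higher number from compound 1 to compound 2 (0.55 log units; beyond the scatter), indicates that changes on this ring move the number modestly. Compound 4 is therefore expected to give a lower number than compound 3, a step of a 3.0-fold lower number from compound 3 to compound 4 (0.48 log units; beyond the scatter) in this assay. The estimate for compound 4 is 20000 nM, with a range from 7000 nM to 55000 nM.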

Compound 4, half-maximal inhibitory concentration: 25100 nM
Estimate against measurement, compound 4: 1.3-fold (0.10 log units) below; low and high end bracket the measured number.
By their numbers in this assay, from the lowest: compound 1; then compounds 2 and 4 (each within the scatter of the next); then compound 3.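

Compound 4 gives the three substituted compounds a common reference, and they do not all depart from it alike. In this assay, taking away the nitro group, which stood meta to a large group and para to a hydroxy group, gives a 2.4-fold lower number from compound 3 to compound 4 (0.38 log units; beyond the scatter), so nitro at that place goes with a higher number than hydrogen. Methyl cannot be told from hydrogen, with a 1.0-fold higher number from compound 2 to compound 4 (0.01 log units; within the scatter), whereas losing the extra hydroxy of compound 1 gives a 3.7-fold higher number from compound 1 to compound 4 (0.56 log units; beyond the scatter), which makes that hydroxy the only one of the three added groups that goes with a lower number than compound 4 shows.

On these data alone, it stays open whether a methoxy group or an amine on the carbon that carries this hydroxy in compound 1 would keep the lower number, and whether a carboxylic acid in place of the nitro group would raise the number as nitro does. The compounds shown come with no measurement that explains any of these steps.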